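Chloro Added to the Shared Core of a Benzyl Purine

The source may report more compounds than this note shows. Statements on the series, on what has been measured and on what is new or still open speak of the compounds shown alone.

Measured so far:
Compound 1, `ClCc1cccc(Cn2cnc3c(Cl)ncnc32)c1`, gives 2630 nM in a functional assay on HOP-62 cells (Homo sapiens) for cytotoxicity, read by sulforhodamine B assay, with a stated time of 48 h; on this read-out higher numbers stand for weaker inhibition of growth and lower numbers for stronger inhibition of growth.
Compound 2, `ClCc1ccc(Cn2cnc3nc(Cl)nc(Cl)c32)cc1`, gives 1900 nM in this assay.

Compound 1 stands as one of two numbers in this assay, and the number for compound 2 lies within the usual scatter of it, so the two cannot be set in order. The pair differs in more than one place, so only their two values can be compared.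

Compound 3, `ClCc1cccc(Cn2cnc3c(Cl)nc(Cl)nc32)c1`, has not yet been measured. It differs from compound 1 by chloro in place of hydrogen on an aromatic carbon — the chloro sits between two ring nitrogen atoms, meta to the chloro group already present and meta and para to the fused ring. Going by the values given here, no measured pair shows this single change. In the absence of such a step, the expected step is small, a 1.3-fold lower number from compound 1 to compound 3 (0.12 log units; within the scatter), no further than the scatter and leaning slightly toward a lower number. Compound 3 is therefore estimated at 2000 nM, with a range from 800 nM to 5000 nM.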

Compound 3, concentration for 50% growth inhibition: 2290 nM
Estimate against measurement, compound 3: 1.1-fold (0.06 log units) below; the measured number falls inside the stated range.
By their numbers in this assay, from the lowest: compounds 2, 3 and 1 (each within the scatter of the next).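

Going by these compounds alone, with the first step in this set that turns on a single change, chloro in place of hydrogen on an aromatic carbon between two ring nitrogen atoms gives a 1.1-fold lower number from compound 1 to compound 3 (0.06 log units; within the scatter) in this assay. At this position, then, the added chloro leaves compound 3 within the scatter of compound 1, and the two cannot be set in order. Nothing measured here accounts for this result.

The compounds shown leave open whether an amine or a methoxy group on this same aromatic carbon would give a number beyond the scatter of compound 1. They also leave open whether the chloro step would stay this small on a shared core carrying a different group in place of the other chloro group, such as an amine.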